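Substituent changes on the distal phenyl ring

A few compounds are considered here, and "the series" means these few. Any claim that something is new, unique, unknown or untested is made for them only; others in the source may bear on it.

Measured so far:
compound 1, `Cn1cc(/C=C2/C(=O)Nc3ccccc32)c2cc(Nc3nccc(-c4ccccc4)n3)ccc21`, in a functional assay on LNCaP cells (Homo sapiens) for cytotoxicity, read by MTT assay, with a stated time of 48 h; on this read-out higher numbers stand for weaker inhibition and lower numbers for stronger inhibition: 13400 nM
compound 2, `COc1ccc(-c2ccnc(Nc3ccc4c(c3)c(/C=C3/C(=O)Nc5ccccc53)cn4C)n2)cc1`, in this assay: > 100000 nM (a limit)
compound 3, `Cn1cc(/C=C2/C(=O)Nc3ccccc32)c2cc(Nc3nccc(-c4ccc(C(F)(F)F)cc4)n3)ccc21`, in this assay: > 100000 nM (a limit)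

Compound 3 gives only a limit in this assay, > 100000 nM, and so has no number of its own. Its position is fixed only by the step of an at least 7.4-fold higher number from compound 1 to compound 3 (0.87 log units; beyond the scatter), which is beyond the scatter. Compound 2 likewise sits at the limit, (the limit of > 100000 nM in this assay, at which 2 of the 3 values shown sit), so the step that the two limits leave unreadable from compound 2 to compound 3 cannot be read.

Compound 4 `Cn1cc(/C=C2/C(=O)Nc3ccccc32)c2cc(Nc3nccc(-c4ccc(Cl)cc4Cl)n3)ccc21` differs from compound 3 by 2,4-dichlorophenyl in place of 4-(trifluoromethyl)phenyl on an aromatic carbon. Going by the values given here, the steps that bear on this are an at least 7.4-fold higher number from compound 1 to compound 2 (0.87 log units; beyond the scatter) and an at least 7.4-fold higher number from compound 1 to compound 3 (0.87 log units; beyond the scatter): both put a group on the phenyl and both moved the number to the limit. Among the compounds with values here, no measured step covers a chloro group or a second substituent, so the estimate rests on the pattern of those two steps alone, with compound 1 the only compound showing a number.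

Compound 4 is therefore expected to remain weak, with an estimate of 60000 nM, range 15000 nM to 150000 nM. The step of an at least 1.6-fold lower number from compound 3 to compound 4 (0.22 log units; that floor lies within the scatter) is expected to stay unreadable against a limit.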

Compound 4, half-maximal inhibitory concentration: > 100000 nM
Compound 4: only a limit was reported; the forecaster's own chance of this, stated with the estimate: 55%; at least 1.6-fold (0.22 log units) between middle value and limit.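

Going by these compounds alone, the change from phenyl to 2,4-dichlorophenyl gives an at least 7.4-fold higher number from compound 1 to compound 4 (0.87 log units; beyond the scatter) in this assay, so a chloro pair on the distal phenyl behaves here like the single 4-methoxy and 4-trifluoromethyl groups. Among the compounds shown, every substituted phenyl now ends at the same ceiling, and only compound 1, with the bare phenyl, goes against this by giving a number: the limit of > 100000 nM in this assay, at which 3 of the 4 values shown sit. The steps among compound 2, compound 3 and compound 4 cannot be read, as each joins two limits, so no order among these three substituted phenyl groups can be given.

From the compounds shown here alone, it remains open whether any group on this phenyl keeps a measurable value. A single fluorine, an amine or a carboxylic acid would test whether the loss extends beyond the groups shown, and whether any substituent can improve on compound 1.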